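Chloro-to-fluoro swap on the sulfonamide aryl ring

The source may report more compounds than this note shows. Statements on the series, on what has been measured and on what is new or still open speak of the compounds shown alone.

Compound 1 `O=S(=O)(Nc1ccc(Cl)c(Cl)c1)c1ccc(-c2cnc(C3CC3)o2)cc1`, compound 2 `O=S(=O)(Nc1ccc(F)c(Cl)c1)c1ccc(-c2cnc(C3CC3)o2)cc1` and compound 3 `Cc1cc(Cl)cc(NS(=O)(=O)c2ccc(-c3cnc(C4CC4)o3)cc2)c1` share one core and differ only in the aryl group on the sulfonamide nitrogen. In a functional assay on cells (leukaemia cell line, Homo sapiens) for inhibition, read by sulforhodamine B assay, with a stated time of 48 h (on this read-out higher numbers stand for weaker inhibition of growth and lower numbers for stronger inhibition of growth), compound 1 gives 416 nM, compound 2 gives 260 nM and compound 3 gives 175 nM. The core change 3-chloro-5-methylphenyl in place of 3,4-dichlorophenyl on a sulfonamide nitrogen gives a 2.4-fold lower number from compound 1 to compound 3 (0.38 log units; beyond the scatter), while a 1.5-fold lower number from compound 2 to compound 3 (0.17 log units; within the scatter). The change fluoro in place of chloro on an aromatic carbon gave a 1.6-fold lower number from compound 1 to compound 2 (0.20 log units; within the scatter). Compound 4 `Cc1cc(F)cc(NS(=O)(=O)c2ccc(-c3cnc(C4CC4)o3)cc2)c1` carries the same kind of change, (fluoro in place of chloro on an aromatic carbon), but at a different place: meta to a large group and meta to a methyl group, not ortho to a chloro group and para to a large group. Since the earlier step from compound 1 to compound 2 was a 1.6-fold lower number from compound 1 to compound 2 (0.20 log units; within the scatter), a similarly small step is expected, a 1.2-fold lower number from compound 3 to compound 4 (0.07 log units; within the scatter). Compound 4 is estimated at 150 nM in this assay, between 70 nM and 400 nM.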

Compound 4, concentration for 50% growth inhibition: 138 nM
Compound 4: middle estimate off by 1.1-fold (0.04 log units), on the high side, and the stated range covers the measured number.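

Fluoro in place of chloro gives a 1.3-fold lower number from compound 3 to compound 4 (0.10 log units; within the scatter) in this assay, and the size of the step carries from one aryl setting to the other without a detectable difference: the same change on two cores in this assay, a 1.6-fold lower number (0.20 log units; within the scatter) from compound 1 to compound 2 and a 1.3-fold lower number (0.10 log units; within the scatter) from compound 3 to compound 4, 1.3-fold (0.10 log units) apart, within the scatter of two such steps. The wider aryl replacements give a 1.9-fold lower number from compound 2 to compound 4 (0.28 log units; within the scatter) and a 3.0-fold lower number from compound 1 to compound 4 (0.48 log units; beyond the scatter), and only the second lies beyond the scatter. This shows that the exchange stays small in these two settings; it does not show a real gain from fluoro in either, nor that the step would hold at other ring places or on other cores.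

Open, going by these compounds, are aryl groups carrying an amine or a carboxylic acid. Also open, on these data alone, is a longer chain on the sulfonamide nitrogen in place of the aryl group.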